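Swapping the Aryl Group: From Compound 1 to Compound 3

The source may report more compounds than this note shows. Statements on the series, on what has been measured and on what is new or still open speak of the compounds shown alone.

compound 1 `COc1ccc(-c2nc3cccc(-c4cc(OC)c(OC)c(OC)c4)c3o2)cc1F`: 2800 nM
compound 2 `COc1cc(-c2cccc3nc(-c4cccc(C)c4)oc23)cc(OC)c1OC`: > 25000 nM

Among the compounds with values here, in a functional assay on NCI-H460 cells (Homo sapiens) for antiproliferative activity, read by MTT assay, with a stated time of 48 h (a lower number here means a stronger inhibitor, a higher number a weaker inhibitor), compound 1 gives 2800 nM, the only plain number in this set. Compound 2 is recorded only as a limit, > 25000 nM, and the limit of > 25000 nM in this assay, at which 1 of the 2 values shown sits, marks where it sits. Within the data shown here, the one measured step, an at least 8.9-fold higher number from compound 1 to compound 2 (0.95 log units; beyond the scatter), is the only evidence for what a change at this aromatic carbon does, and it runs toward weaker inhibition.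

Compound 3 `COc1cc(-c2cccc3nc(-c4cccc(O)c4)oc23)cc(OC)c1OC` differs from compound 1 as follows: 3-hydroxyphenyl in place of 3-fluoro-4-methoxyphenyl on an aromatic carbon. That step touches the same position as the measured one, so the expectation for compound 3 is a higher number than for compound 1, in the weaker direction, with the step estimated as a 5.4-fold higher number from compound 1 to compound 3 (0.73 log units; beyond the scatter). Compound 3 is therefore estimated at 15000 nM, with a range from 4000 nM to 40000 nM, and a real chance that only a limit is reported.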

Compound 3, half-maximal inhibitory concentration: 1900 nM
Compound 3: the middle estimate sits 7.9-fold (0.90 log units) above what was measured, outside the stated range (below it).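

In this assay, placing 3-hydroxyphenyl where 3-fluoro-4-methoxyphenyl stood gives a 1.5-fold lower number from compound 1 to compound 3 (0.17 log units; within the scatter), so the two aryl groups cannot be told apart here and a change at this aromatic carbon does not by itself weaken the compound. The sharper contrast is hydroxy against methyl on the aryl ring, with an at least 13-fold lower number from compound 2 to compound 3 (1.11 log units; beyond the scatter), which ties the weak reading to the 3-methylphenyl group and not to the position as such. That step has a limit at one end, since compound 2 is recorded only as a limit: the limit of > 25000 nM in this assay, at which 1 of the 3 values shown sits.

Whether the hydroxy group itself is what matters remains open, and the compounds shown do not tell how an amine or a carboxylic acid in its place would read. Nor do they separate the contributions of the fluoro and methoxy groups in compound 1.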